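Butoxy in place of methoxymethyl on the shared core

The source may hold more compounds than are shown below. What is called first, only, known or untested is meant among the compounds shown, and "the series" means these compounds.

Compound 2 `COCc1cccc(Cc2cnc(N)nc2N)c1` gives 5.28 in a functional assay on L5178Y cells (Mus musculus) for inhibition (on this read-out higher numbers stand for higher potency (the scale is a negative logarithm) and lower numbers for lower potency), and is the higher of the two measured compounds. Compound 1 `Nc1ncc(Cc2cc(CO)cc(CO)c2)c(N)n1` gives 3.79 in this assay, a number that lies beyond the scatter below compound 2.

Compound 3 `CCCCOc1cccc(Cc2cnc(N)nc2N)c1` differs from compound 2 in one place: butoxy in place of methoxymethyl on an aromatic carbon. Among the measured compounds shown here, no measured pair shows a step of this kind, so the expectation rests on compound 2 alone. A modest gain is expected, with the step of a number 0.52 log units higher from compound 2 to compound 3 (beyond the scatter) judged small and upward, since compound 2 already sits at 5.28. Compound 3 is therefore estimated at 5.8, within a range from 5 to 6.6.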

Compound 3, logarithm of the reciprocal of the active concentration, log(1/C): 5.74
The estimate for compound 3 lay 0.06 log units above the measured number, within the range that was stated.
By their numbers in this assay, from the lowest: compound 1; then compound 2; then compound 3.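

In this assay, butoxy in place of methoxymethyl on this aromatic carbon gives a number 0.46 log units higher from compound 2 to compound 3 (beyond the scatter). Among the compounds shown here, this is the only step between compounds differing in one place, and it shows that the number responds to the group carried here and that the larger butoxy group does not lower it. Nothing shown accounts for the step. As far as these compounds go, whether it follows the length of the chain or the placing of its oxygen stays open, as one pair cannot separate the two. Ethoxy, a longer hexyloxy chain or an amine on this aromatic carbon would bear on that question.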